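From Thiophen-2-yl to 4-Fluorophenyl on the Amide Carbonyl

The source may hold more compounds than are shown below. What is called first, only, known or untested is meant among the compounds shown, and "the series" means these compounds.

Compound 1 `CN(C)c1cc2[nH]c(C3CCCCC3)nc2cc1NC(=O)c1cccs1`: > 100 ug/mL
Compound 2 `CCN(CC)c1cc2[nH]c(C3CCCCC3)nc2cc1NC(=O)OCC(F)(F)F`: > 100 ug/mL
Compound 3 `CCN(CC)c1cc2[nH]c(C3CCCCC3)nc2cc1NC(=O)c1ccc(OC(F)(F)F)cc1`: > 100 ug/mL

In an ADME assay on Vero cells (Chlorocebus sabaeus) for cytotoxicity, read by resazurin assay, with a stated time of 3 days (a lower number here means a stronger inhibitor, a higher number a weaker inhibitor), compound 1 gives > 100 ug/mL, which is a limit of the assay rather than a number. Compound 2 and compound 3 sit at the same limit, so the step that the two limits leave unreadable from compound 2 to compound 3 cannot be read in size; the limit of > 100 ug/mL in this assay, at which 3 of the 3 values shown sit, shows where every value stands. Compound 4 `CN(C)c1cc2[nH]c(C3CCCCC3)nc2cc1NC(=O)c1ccc(F)cc1` differs from compound 1 by 4-fluorophenyl in place of thiophen-2-yl on a carbonyl carbon. For the measured compounds named here, no measured step carries this change, and the values shown give no room to read any movement. Compound 4 is therefore expected to stay at the limit, with the step of a number no higher from compound 1 to compound 4 (the limit leaves the size open) expected to be none beyond the scatter. The estimate for compound 4 is 100 ug/mL, in the range 50 ug/mL to 200 ug/mL.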

Compound 4, half-maximal inhibitory concentration: > 100 ug/mL
Compound 4: only a limit was reported; the forecaster's own chance of this, stated with the estimate: 85%; the middle value sits exactly at the limit.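

In this assay compound 1 and compound 4 both stand at a limit rather than a number, so no step between them can be read: the limit of > 100 ug/mL in this assay, at which 4 of the 4 values shown sit.

The compounds shown leave open whether 4-fluorophenyl in place of thiophen-2-yl on a carbonyl carbon changes cytotoxicity at all.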